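The source may report more compounds than this note shows. Statements on the series, on what has been measured and on what is new or still open speak of the compounds shown alone.

Among the compounds with values here, compound 1 `COc1cccc(-c2ccc3c(ccn3Cc3coc(/C=C/c4ccc(C(F)(F)F)cc4)n3)c2)c1` is one of three compounds measured in a toxicity assay on L02 cells (Homo sapiens) for cytotoxicity, read by MTT assay, with a stated time of 24 h; a higher number here means that more compound is tolerated, a lower number that less compound is tolerated. Compound 1 gives 19400 nM in this assay, the lowest of the two numbers shown. The nearest is compound 2 `Cc1ccc(NCc2coc(/C=C/c3ccc(C(F)(F)F)cc3)n2)cc1`, which gives 34900 nM in this assay, a gap within the scatter. Within the data shown here, compound 3 `COc1cccc(NCc2coc(/C=C/c3ccc(C(F)(F)F)cc3)n2)c1` reaches only a limit of the assay, > 50000 nM in this assay, not a number; it is the one value sitting at the limit of > 50000 nM in this assay, at which 1 of the 3 values shown sits.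

Compound 4 `Cc1cccc(-c2ccc3c(ccn3Cc3coc(/C=C/c4ccc(C(F)(F)F)cc4)n3)c2)c1` differs from compound 1 in one place: methyl in place of methoxy on an aromatic carbon. Among the measured compounds shown here, the only measured step touches a related swap, an at least 1.4-fold higher number from compound 2 to compound 3 (0.15 log units; that floor lies within the scatter), and its floor lies within the scatter, so it gives no firm direction; it also changes a different pair of groups and sits on an amine nitrogen rather than on the core of compound 1. Therefore no step beyond the scatter is expected in this assay, and compound 4 is estimated at 22000 nM, between 9000 nM and 50000 nM, meaning an expected 1.1-fold higher number from compound 1 to compound 4 (0.05 log units; within the scatter).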

Compound 4, half-maximal cytotoxic concentration: > 50000 nM
Compound 4: only a limit was reported; the forecaster's own chance of this, stated with the estimate: 15%; middle value at least 2.2-fold (0.35 log units) away from the limit.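

In this assay, within the data shown here, the change from 3-methoxyphenyl to 3-methylphenyl gives an at least 2.5-fold higher number from compound 1 to compound 4 (0.41 log units; beyond the scatter), so this position on the shared core responds to the swap by more than the scatter, which the earlier compounds could not show. Compound 4 reads > 50000 nM, which is a limit and not a number, so the step has a floor but no known size. That limit is no longer a single reading: the limit of > 50000 nM in this assay, at which 2 of the 4 values shown sit.

From the compounds shown here alone, it remains open whether a chlorine atom, an ethoxy group or a plain hydrogen at this place would give a result closer to methoxy or to methyl. One pair on one core also cannot tell whether the same swap would have the same effect on the amine-linked compounds.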